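The source may hold more compounds than are shown below. What is called first, only, known or untested is meant among the compounds shown, and "the series" means these compounds.

Compound 3 `Cc1ccc(-c2cc(-c3ccc(Cl)o3)cc(-c3ccc(Cl)s3)n2)cc1` gives only a limit in a functional assay on DU-145 cells (Homo sapiens) for cytotoxicity, read by ELISA, with a stated time of 4 days (on this read-out higher numbers stand for weaker inhibition and lower numbers for stronger inhibition), > 50000 nM, and no number. Compound 4 `Clc1cccc(-c2cc(-c3ccc(Cl)o3)cc(-c3ccc(Cl)s3)n2)c1` has 3-chlorophenyl in place of 4-methylphenyl on an aromatic carbon, and keeps the 5-chlorofuran-2-yl and 5-chlorothiophen-2-yl groups. Going by the values given here, no two measured compounds differ in one place only. In this assay compound 1 `Clc1cccc(-c2cc(-c3ccoc3)cc(-c3ccc(Cl)s3)n2)c1` reads 23000 nM, and compound 2 `Cc1ccsc1-c1cc(-c2ccc(Cl)o2)cc(-c2cccc(Cl)c2)n1` reads 20500 nM; these two values lie within the scatter of each other, and both compounds carry 3-chlorophenyl. On those two values, the expected step of an at least 2.0-fold lower number from compound 3 to compound 4 (0.30 log units; that floor lies within the scatter) points towards stronger inhibition, and its size stays uncertain. For compound 4 the estimated value is 25000 nM, with an expected range of 11000 nM to 55000 nM.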

Compound 4, half-maximal inhibitory concentration: 21600 nM
Compound 4: middle estimate off by 1.2-fold (0.06 log units), on the high side; low and high end bracket the measured number.
By their numbers in this assay, from the lowest: compounds 2, 4 and 1 (each within the scatter of the next). At a limit, above all of these: compound 3.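

In this assay, going by these compounds alone, the switch to 3-chlorophenyl in place of 4-methylphenyl, on the aromatic carbon next to the ring nitrogen, gives the first single-place step at this position (an at least 2.3-fold lower number from compound 3 to compound 4 (0.36 log units; beyond the scatter)). Compound 4 also connects to the earlier 3-chlorophenyl compounds, with neither exchange elsewhere moving the number beyond the scatter (a 1.1-fold higher number from compound 2 to compound 4 (0.02 log units; within the scatter); a 1.1-fold lower number from compound 1 to compound 4 (0.03 log units; within the scatter)). Compound 3 stands only as a limit (> 50000 nM), so the full size of the first step remains unread. The chlorine and its ring position are not separated here. Going by these compounds, how a dimethylamino group or a carboxylic acid on this phenyl ring would read remains open.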